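Swapping an Amine Tail for a Hydroxyl Tail

A few compounds are considered here, and "the series" means these few. Any claim that something is new, unique, unknown or untested is made for them only; others in the source may bear on it.

Compound 1 `C=CCCn1cnc2c1c(=O)n(C)c(=O)n2CCC`: 6000 nM
Compound 2 `CCCn1c(=O)n(C)c(=O)c2c1ncn2CCCN(C)C`: > 200000 nM

In an assay on Cerebral cortex for binding affinity to adenosine receptor A1 (Cavia porcellus), read by radioligand binding (on this read-out lower numbers stand for stronger inhibition and higher numbers for weaker inhibition), compound 1 gives 6000 nM. For compound 2 only a limit is known, > 200000 nM, which is a boundary of the assay rather than a number (the limit of > 200000 nM in this assay, at which 1 of the 2 values shown sits). Compound 3 `CCCn1c(=O)n(C)c(=O)c2c1ncn2CCO` carries hydroxy in place of (dimethylamino)methyl on a saturated chain carbon, two bonds along the chain from an aromatic nitrogen. Among the measured compounds shown here, the one measured step that bears on it is an at least 33-fold higher number from compound 1 to compound 2 (1.52 log units; beyond the scatter), where the (dimethylamino)methyl group arrived. Taking it away again is expected to move the number back downward, by an at least 10-fold lower number from compound 2 to compound 3 (1.00 log units; beyond the scatter). Compound 3 is therefore expected to come in at 20000 nM, within 3000 nM to 150000 nM.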

Compound 3, inhibition constant: 41400 nM
Beside the measured number, compound 3's estimate is 2.1-fold (0.32 log units) below it, and the stated range covers the measured number.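

At this position on the chain, the hydroxy group partly undoes the loss seen with the amine tail, giving an at least 4.8-fold lower number from compound 2 to compound 3 (0.68 log units; beyond the scatter). That step is only a minimum, as one end of it is a limit of the assay and not a number: the limit of > 200000 nM in this assay, at which 1 of the 3 values shown sits. The recovery stays incomplete, with a 6.9-fold higher number from compound 1 to compound 3 (0.84 log units; beyond the scatter), so the vinyl-ended chain still gives the lowest number of the three.

The 2-hydroxyethyl tail is also shorter than the 3-(dimethylamino)propyl tail, so the effects of end group and chain length cannot be told apart. Going by these compounds, how a 3-hydroxypropyl chain or a carboxylic acid would fare remains open.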